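Methoxy removal on the pendant aryl ring

The source may report more compounds than this note shows. Statements on the series, on what has been measured and on what is new or still open speak of the compounds shown alone.

Compound 2 `COc1ccc(-c2[nH]c3ccc(OC)cc3c2/C=C(\C#N)S(=O)(=O)c2ccccc2)cc1`: 1700 nM
Compound 1 `COc1ccc(-c2[nH]c3ccccc3c2/C=C(\C#N)S(=O)(=O)c2ccccc2)cc1`: 3000 nM

Among the measured compounds shown here, in a functional assay on NCI-H522 cells (Homo sapiens) for inhibition, read by sulforhodamine B assay, with a stated time of 48 h (a lower number here means a stronger inhibitor of growth, a higher number a weaker inhibitor of growth), compound 2 gives 1700 nM, the lowest of the two numbers measured so far. Compound 1 gives 3000 nM, and the step of a 1.8-fold lower number from compound 1 to compound 2 (0.25 log units; within the scatter) shows that adding a methoxy on the shared core left the growth inhibition essentially unchanged.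

Compound 3 `COc1ccc2[nH]c(-c3ccccc3)c(/C=C(\C#N)S(=O)(=O)c3ccccc3)c2c1` has not been measured. It differs from compound 2 by hydrogen in place of methoxy on an aromatic carbon; seen one bond further out, a 4-methoxyphenyl becomes a phenyl, while the methoxy on the shared core of compound 2 stays in place.

For the measured compounds named here, no measured pair probes the methoxy on this aryl ring, so there is no direct precedent. Going by the values given here, the only step available, from compound 1 to compound 2, concerns a methoxy elsewhere and was within the scatter. The expectation is therefore a small step, in no clear direction: the estimated step of a 1.3-fold higher number from compound 2 to compound 3 (0.11 log units; within the scatter) stays inside the usual scatter. Compound 3 is estimated at 2200 nM, with a range from 800 nM to 6000 nM that reflects the absence of a matched precedent.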

Compound 3, concentration for 50% growth inhibition: 4000 nM
Compound 3: the middle estimate sits 1.8-fold (0.26 log units) below what was measured; the range from low to high includes it.
By their numbers in this assay, from the lowest: compounds 2, 1 and 3 (each within the scatter of the next, the first and the last beyond it).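

In this assay, the change from 4-methoxyphenyl to phenyl gives a 2.4-fold higher number from compound 2 to compound 3 (0.37 log units; beyond the scatter), making it the first single change among these compounds to lie beyond the scatter, though only modestly. Among the compounds shown here, the methoxy on the shared core gave a 1.8-fold lower number from compound 1 to compound 2 (0.25 log units; within the scatter), so of the two methoxy groups in compound 2, only the one on the pendant aryl ring, para to a large group, has a readable link to growth inhibition. Nothing available explains why removing this methoxy weakens growth inhibition or why it matters more than the methoxy on the core.

The compounds shown leave open whether the methoxy on the aryl ring is specifically favourable or whether another group there, such as a hydroxyl, an amine, a chlorine or a longer ethoxy chain, would match or surpass it. They also leave open whether the loss seen on removing this methoxy would be the same size on a core without its own methoxy, since both compounds in this step carry that group.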